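The source may hold more compounds than are shown below. What is called first, only, known or untested is meant among the compounds shown, and "the series" means these compounds.

Measured so far in an assay on isolated protein for inhibition of alkaline phosphatase, tissue-nonspecific isozyme (Homo sapiens); on this read-out lower numbers stand for stronger inhibition and higher numbers for weaker inhibition:
Compound 1 `COc1ccc(Cl)cc1S(=O)(=O)Nc1cncc(-c2cccnc2)c1` — 73 nM
Compound 2 `COc1ccc(C#N)cc1S(=O)(=O)Nc1cnc2ccccc2c1` — 38 nM

In this assay compound 1 gives 73 nM, the higher of the two numbers; compound 2 gives 38 nM, and the gap between them lies within the scatter, so the two cannot be told apart.

Compound 3 `COC(=O)c1cncc(NS(=O)(=O)c2cc(Cl)ccc2OC)c1` differs from compound 1 by methoxycarbonyl in place of pyridin-3-yl on an aromatic carbon, in words: methoxycarbonyl in place of pyridin-3-yl on an aromatic carbon. Within the data shown here, no measured pair shows a change of this kind, so the expected step is a 2.1-fold higher number from compound 1 to compound 3 (0.31 log units; beyond the scatter), a small rise in the number that may not clear the scatter. Compound 3 is expected to give 150 nM, within 40 nM to 600 nM.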

Compound 3, half-maximal inhibitory concentration: 65 nM
For compound 3 the middle estimate is 2.3-fold (0.36 log units) above the measured one; measured number inside the range.
By their numbers in this assay, from the lowest: compounds 2, 3 and 1 (each within the scatter of the next).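

In this assay putting methoxycarbonyl in place of pyridin-3-yl gives a 1.1-fold lower number from compound 1 to compound 3 (0.05 log units; within the scatter) and so leaves the two compounds indistinguishable. At this position, two atoms from the ring nitrogen, a group with no ring and fewer heavy atoms can therefore take the place of an aromatic ring without a difference beyond the scatter. No evidence in hand bears on why the two groups read alike. Still open, on these data alone, is whether a carboxylic acid or an amine at this position would read the same, and how a longer chain would compare.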